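From carbamoyl to chloro in compound 4

The source may report more compounds than this note shows. Statements on the series, on what has been measured and on what is new or still open speak of the compounds shown alone.

In a functional assay (aorta) with Oryctolagus cuniculus as the target (a higher number here means weaker binding, a lower number tighter binding), compound 1 `COc1cc(C(=O)O)ccc1OCCCN1CCC(C(c2ccc(F)cc2)c2ccc(F)cc2)CC1` gives 79.4 nM and compound 2 `COc1cc(OCCCN2CCC(C(c3ccc(F)cc3)c3ccc(F)cc3)CC2)ccc1C(C)=O` gives 3.16 nM while compound 3 `NC(=O)c1ccc(OCCCN2CCC(C(c3ccc(F)cc3)c3ccc(F)cc3)CC2)cc1` sits between them at 31.6 nM on this scale. Compound 4 `Fc1ccc(C(c2ccc(F)cc2)C2CCN(CCCOc3ccc(Cl)cc3)CC2)cc1` differs from compound 3 by a single change chloro in place of carbamoyl on an aromatic carbon that reads as chloro in place of carbamoyl on an aromatic carbon.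

Within the data shown here, no measured step makes this exact swap, so the evidence is indirect. Among the measured compounds shown here, three steps bear on it: a 10-fold higher number from compound 2 to compound 3 (1.00 log units; beyond the scatter) and a 2.5-fold lower number from compound 1 to compound 3 (0.40 log units; beyond the scatter) are both modest, while a 25-fold lower number from compound 1 to compound 2 (1.40 log units; beyond the scatter) is large. Among these three, only compound 2 carries neither carboxy nor carbamoyl, and it has the lowest number at 3.16 nM in this assay so far. Compound 4 also lacks both groups, but it lacks the acetyl and methoxy groups of compound 2 as well, so only a modest move towards a lower number is expected. The estimated step is a 3.2-fold lower number from compound 3 to compound 4 (0.50 log units; beyond the scatter) in size. Compound 4 is expected at 10 nM with 2.5 nM to 40 nM as the estimated range.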

Compound 4, dissociation constant: 2 nM
Beside the measured number, compound 4's estimate is 5.0-fold (0.70 log units) above it; measured number outside the range, below it.
By their numbers in this assay, from the lowest: compounds 4 and 2 (each within the scatter of the next); then compound 3; then compound 1.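

In this assay, chloro in place of carbamoyl, para to a large group, brings (a 16-fold lower number from compound 3 to compound 4 (1.20 log units; beyond the scatter)), so a low number at this place on the ring needs neither a carbonyl nor a hydrogen-bond donor. The acetyl and methoxy groups of compound 2 are not needed for a low number either, since the change to 4-chlorophenyl gives (a 1.6-fold lower number from compound 2 to compound 4 (0.20 log units; within the scatter)), while the change from the acid-bearing ring gives (a 40-fold lower number from compound 1 to compound 4 (1.60 log units; beyond the scatter)). No measurement shown here offers an explanation for these steps.

On these data alone, whether bromo, fluoro or an amine at this same place would keep the number as low as chloro does stays open. So does the effect of a longer chain between the oxygen and the shared core.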